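Swapping a Branched Chain for a Methoxyphenyl Ring

The source may hold more compounds than are shown below. What is called first, only, known or untested is meant among the compounds shown, and "the series" means these compounds.

Compound 1 `CC(C)COc1cc(C(F)(F)F)ccc1CNC(=O)C(C)c1ccc(NS(C)(=O)=O)c(F)c1`: 0.8 nM
Compound 2 `CC(C)CCSc1cc(C(F)(F)F)ccc1CNC(=O)C(C)c1ccc(NS(C)(=O)=O)c(F)c1`: 1.4 nM

Both compounds were tested in an assay on CHO cells for antagonist activity at transient receptor potential cation channel subfamily V member 1 (Homo sapiens), read by FLIPR; on this read-out higher numbers stand for weaker inhibition and lower numbers for stronger inhibition. Compound 2 has the higher of the two numbers, yet its separation from compound 1 is only a 1.8-fold higher number from compound 1 to compound 2 (0.24 log units; within the scatter), so the two cannot be told apart with confidence.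

Compound 3 `COc1ccc(CSc2cc(C(F)(F)F)ccc2CNC(=O)C(C)c2ccc(NS(C)(=O)=O)c(F)c2)cc1` is the unmeasured partner of compound 2. The change is 4-methoxyphenyl in place of isobutyl on a saturated chain carbon bound to a sulfur, so a branched chain is replaced by an aromatic ring bearing an oxygen acceptor. Within the data shown here, the only measured step touches the same side chain, changing isobutoxy to isopentylsulfanyl, and it moved the number by just a 1.8-fold higher number from compound 1 to compound 2 (0.24 log units; within the scatter). Among the measured compounds shown here, that step shows the chain tolerating small edits, but no measured pair tests a ring in this place, so the expectation rests on weak ground and is kept wide.

Compound 3 is expected to give 2.5 nM, within 0.6 nM to 10 nM. That expectation amounts to a 1.8-fold higher number from compound 2 to compound 3 (0.25 log units; within the scatter).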

Compound 3, inhibition constant: 2.3 nM
Beside the measured number, compound 3's estimate is 1.1-fold (0.04 log units) above it; the measured number falls inside the stated range.
By their numbers in this assay, from the lowest: compounds 1, 2 and 3 (each within the scatter of the next, the first and the last beyond it).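

In this assay, the chain bound to the sulfur accepts an aromatic ring as well as a branched chain: 4-methoxyphenyl in place of isobutyl leaves compound 3 not clearly separated from compound 2 (a 1.6-fold higher number from compound 2 to compound 3 (0.22 log units; within the scatter)). Set against the isobutoxy group of compound 1, however, the (4-methoxybenzyl)sulfanyl group does show a real, though modest, loss of inhibition (a 2.9-fold higher number from compound 1 to compound 3 (0.46 log units; beyond the scatter)), the only gap among these compounds that clears the scatter. That comparison changes the whole side chain at once and cannot show which part accounts for the gap, and nothing measured here gives a reason for it.

Still open, going by these compounds, is whether the ring needs its methoxy group, or would accept an amine or a carboxylic acid there instead. A (4-methoxybenzyl)oxy group in place of the (4-methoxybenzyl)sulfanyl group would also remain to be compared.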